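The compounds below may be only part of what the source reports. "The series", "measured", "known", "first", "only" and "open" are said of these compounds alone.

In an ADME assay on microsomes from liver (Homo sapiens) for metabolic stability, read by LC-MS, tested at 1 mM (on this read-out lower numbers stand for a shorter-lived compound and higher numbers for a longer-lived compound), the shared core was tested in three forms. Compound 1 `CS(=O)(=O)c1cccc(-c2c[nH]c3c(=O)n(Cc4cc(F)ccc4C#N)c(N4CCC[C@@H](N)C4)nc23)c1` gives > 3.33 h, which is a limit of the assay rather than a number. Compound 2 `CS(=O)(=O)c1ccccc1-c1c[nH]c2c(=O)n(Cc3cc(F)ccc3C#N)c(N3CCC[C@@H](N)C3)nc12` likewise gives > 3.33 h, again a limit. Going by the values given here, compound 3 `N#Cc1ccc(F)cc1Cn1c(N2CCC[C@@H](N)C2)nc2c(F)c[nH]c2c1=O` gives 1.64 h, the only true number among the three. The step of an at least 2.0-fold lower number from compound 1 to compound 3 (0.30 log units; that floor lies within the scatter) and the step of an at least 2.0-fold lower number from compound 2 to compound 3 (0.30 log units; that floor lies within the scatter) both point the same way, although each floor lies within the scatter, and both rest on (the limit of > 3.33 h in this assay, at which 2 of the 3 values shown sit). The step that the two limits leave unreadable from compound 1 to compound 2 cannot be read. Compound 4 `CS(=O)(=O)c1ccc(-c2c[nH]c3c(=O)n(Cc4cc(F)ccc4C#N)c(N4CCC[C@@H](N)C4)nc23)cc1F` is now to be measured in this assay. It differs from compound 3 by 3-fluoro-4-(methylsulfonyl)phenyl in place of fluoro on an aromatic carbon. Both measured steps toward compound 3 removed a methylsulfonyl-bearing phenyl and lowered the number, so the reverse change is expected to raise it, and the step of a 2.4-fold higher number from compound 3 to compound 4 (0.39 log units; beyond the scatter) is the expected size. Compound 4 is therefore estimated to give 4 h in this assay, with a range from 2 h to 8 h, and quite possibly only a limit will be reported.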

Compound 4, half-life: > 3.33 h
Compound 4 ended at the assay's limit; the forecaster's own chance of this, stated with the estimate: 60%; the middle value is on the limit's open side.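

In this assay, putting 3-fluoro-4-(methylsulfonyl)phenyl in place of fluoro, on an aromatic carbon of the five-membered ring two ring bonds from the ring nitrogen, gives an at least 2.0-fold higher number from compound 3 to compound 4 (0.30 log units; that floor lies within the scatter). With compound 1, compound 2 and compound 4 all at the limit, the methylsulfonyl group has now been carried on the phenyl ring in three arrangements, one of them with an added fluoro, and none of the three gives a true number; among the compounds shown, only compound 3, with its single fluoro, does. The steps among these three compounds cannot be read, and the size of the rise over compound 3 stays unknown, because all of them rest on one limit: the limit of > 3.33 h in this assay, at which 3 of the 4 values shown sit.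

The compounds shown leave open whether the methylsulfonyl group is needed at all, a question that a plain phenyl, or a phenyl carrying an amine or a carboxylic acid, at this position could address if it returned a true number. They also leave open whether hydrogen or a methyl group in place of the fluoro of compound 3 would shift the half-life in either direction.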